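Moving the Bromine: 2-Bromophenyl to 4-Bromophenyl

A few compounds are considered here, and "the series" means these few. Any claim that something is new, unique, unknown or untested is made for them only; others in the source may bear on it.

In a functional assay on HT-29 cells (Homo sapiens) for antiproliferative activity, read by sulforhodamine B assay, with a stated time of 72 h (on this read-out higher numbers stand for weaker inhibition and lower numbers for stronger inhibition), compound 1 (`Cc1cccc(NC(=S)N/N=C/c2ccc3ccccc3n2)c1`) reads > 100000 nM and this is a limit, not a number. Going by the values given here, compound 2 (`S=C(NCc1ccccc1)N/N=C/c1ccc2ccccc2n1`) gives 75700 nM as the only true number so far. Compound 3 (`S=C(N/N=C/c1ccc2ccccc2n1)Nc1ccccc1Br`) reads > 100000 nM and this too is a limit, so it stands at the limit of > 100000 nM in this assay, at which 2 of the 3 values shown sit, with no number of its own.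

Compound 4 (`S=C(N/N=C/c1ccc2ccccc2n1)Nc1ccc(Br)cc1`) carries 4-bromophenyl in place of 2-bromophenyl on an amide-type nitrogen. Among the compounds with values here, no measured step makes this change, so the evidence is indirect. The steps nearest to it are an at least 1.3-fold lower number from compound 1 to compound 2 (0.12 log units; that floor lies within the scatter) and an at least 1.3-fold higher number from compound 2 to compound 3 (0.12 log units; that floor lies within the scatter) with both floors within the scatter, while a step that the two limits leave unreadable from compound 1 to compound 3 adds nothing readable. Within the data shown here, with those small floors and with compound 2 at 75700 nM as the sole number, no shift beyond the scatter is expected. The estimated change is an at least 1.1-fold lower number from compound 3 to compound 4 (0.04 log units; that floor lies within the scatter) in this series. In this assay the expected value for compound 4 is 90000 nM with an estimated range from 35000 nM to 200000 nM overall.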

Compound 4, half-maximal inhibitory concentration: 54400 nM
Compound 4: the middle estimate sits 1.7-fold (0.22 log units) above what was measured, within the range that was stated.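

Moving the bromine gives the first bromophenyl compound with a true number in this assay, and the change is an at least 1.8-fold lower number from compound 3 to compound 4 (0.26 log units; that floor lies within the scatter), so this floor alone does not show that the bromine's position matters. Against the benzyl group the change is a 1.4-fold lower number from compound 2 to compound 4 (0.14 log units; within the scatter), which leaves those two compounds indistinguishable, and against 3-methylphenyl it is an at least 1.8-fold lower number from compound 1 to compound 4 (0.26 log units; that floor lies within the scatter), again only a floor within the scatter. Compound 1 and compound 3 remain limits, not numbers: the limit of > 100000 nM in this assay, at which 2 of the 4 values shown sit.

As far as these compounds go, whether any change on this nitrogen moves the read-out beyond the scatter stays open. Also open, from the compounds shown here alone, is how an amine or a carboxylic acid in place of the bromine, or a longer chain in place of benzyl, would read.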